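Swapping chlorophenyl for bromophenyl on a shared core

The source may hold more compounds than are shown below. What is called first, only, known or untested is meant among the compounds shown, and "the series" means these compounds.

Measured so far in an assay on HepG2 cells for agonist activity at nuclear receptor subfamily 1 group I member 3 (Homo sapiens), read by a luciferase reporter, with a stated time of 23 h; on this read-out higher numbers stand for an effect only at larger amounts of compound and lower numbers for an effect already at smaller amounts:
Compound 1 `Clc1ccc(CO/N=C/c2c(-c3cccc4ccccc34)nc3sccn23)cc1Cl` gives 940 nM
Compound 2 `Clc1cccc(-c2nc3sccn3c2/C=N/OCc2ccc(Cl)c(Cl)c2)c1` gives 1100 nM

Within the data shown here, compound 2 stands at 1100 nM in this assay, and the only measured step, a 1.2-fold higher number from compound 1 to compound 2 (0.07 log units; within the scatter), lies within the scatter, so neither compound can be set apart from the other. Compound 3 `Clc1ccc(CO/N=C/c2c(-c3ccc(Br)cc3)nc3sccn23)cc1Cl` differs from compound 2 by 4-bromophenyl in place of 3-chlorophenyl on an aromatic carbon. Among the measured compounds shown here, the one step that bears on this, from compound 1 to compound 2, moved nothing beyond the scatter, so no step beyond the scatter is expected in this assay here either. Compound 3 is therefore estimated at 1100 nM, in a range from 400 nM to 3200 nM. That means an expected step of no change at the digits printed from compound 2 to compound 3 (within the scatter).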

Compound 3, half-maximal effective concentration: 480 nM
Compound 3: middle estimate off by 2.3-fold (0.36 log units), on the high side; the range from low to high includes it.
By their numbers in this assay, from the lowest: compounds 3, 1 and 2 (each within the scatter of the next, the first and the last beyond it).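

Among these compounds, at this position on the shared core, a 2.3-fold lower number from compound 2 to compound 3 (0.36 log units; beyond the scatter) in this assay is the first step beyond the scatter, with 4-bromophenyl entering for 3-chlorophenyl. The same entering group in place of naphthalen-1-yl gives a 2.0-fold lower number from compound 1 to compound 3 (0.29 log units; within the scatter) and stays within the scatter, so the position has so far shown only a modest response. Nothing on hand explains the step. The halogen and its place on the phenyl ring change together, so the compounds shown do not separate the two. On these data alone, how an amine or a carboxylic acid on that ring would read remains open.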